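The source may hold more compounds than are shown below. What is called first, only, known or untested is meant among the compounds shown, and "the series" means these compounds.

Measured compounds:
compound 1 `Cc1ccc(Nc2nnc(Nc3nc(-c4ccc(Br)cc4)cs3)s2)cc1` gives 100 mg/kg
compound 2 `Brc1ccc(-c2csc(Nc3nnc(Nc4ccccc4)s3)n2)cc1` gives 300 mg/kg

Both were tested in a functional assay on the whole organism (strain albino) with Mus musculus as the target, in the maximal electroshock model, with a stated time of 0.5 h; a higher number here means that more compound is needed for the effect, a lower number that less compound is needed. Compound 1 stands at the lowest of the two numbers; its nearest neighbour is compound 2, and the step of a 3.0-fold higher number from compound 1 to compound 2 (0.48 log units; beyond the scatter) separates them, a change in which hydrogen replaces methyl on an aromatic carbon.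

Compound 3 `Cc1ccc(Nc2nnc(Nc3nc(-c4ccccc4)cs3)s2)cc1` has not yet been measured. It differs from compound 1 as follows: hydrogen in place of bromo on an aromatic carbon. The bromo that leaves sits on an aromatic carbon of a six-membered aromatic ring of carbon only.

Within the data shown here, no measured step removes a bromo, so none bears directly on this change. Among the measured compounds shown here, the only measured step, a 3.0-fold higher number from compound 1 to compound 2 (0.48 log units; beyond the scatter), concerns a different group on a different ring. On these data alone, it shows that taking away a small group from an aromatic ring raised the number in this assay beyond the scatter, but whether that carries over to the bromo is unknown. A step of similar or smaller size in the same direction, or none beyond the scatter, is therefore expected.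

Compound 3 is accordingly estimated at 150 mg/kg, with a range from 50 mg/kg to 300 mg/kg. This estimate corresponds to an expected step of a 1.5-fold higher number from compound 1 to compound 3 (0.18 log units; within the scatter) in this assay.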

Compound 3, minimum effective dose: 100 mg/kg
Compound 3: the middle estimate sits 1.5-fold (0.18 log units) above what was measured; the range from low to high includes it.
By their numbers in this assay, from the lowest: compounds 1 and 3 (each within the scatter of the next); then compound 2.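

Going from the 4-bromophenyl to the phenyl gives no change at the digits printed from compound 1 to compound 3 (within the scatter) in this assay, so at this position, on an aromatic carbon para to a large group, the bromo can be lost without a change beyond the scatter. Among these compounds, the earlier compounds could not show this, as their only step, a 3.0-fold higher number from compound 1 to compound 2 (0.48 log units; beyond the scatter), concerns the methyl on the other aromatic ring; within this set, therefore, the methyl change is the one that moves the number beyond the scatter, and the bromo change is not. The data given here offer no explanation for why the two changes differ in this way.

The compounds shown leave open whether this position accepts other groups as well, such as a methoxy, an amine or a carboxylic acid, or whether one of them would move the number beyond the scatter. They also leave open whether the bromo change would read the same on compound 2 , which carries the bromo but lacks the methyl.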